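From octyl to cyclopentyl on sulfur

The compounds below may be only part of what the source reports. "The series", "measured", "known", "first", "only" and "open" are said of these compounds alone.

In an ADME assay on CCRF-HSB-2 cells (Homo sapiens) for cytotoxicity, with a stated time of 7 days (a lower number here means that less compound is tolerated, a higher number that more compound is tolerated), compound 1 (`Nc1nc(NC2CCCC2)c2ncn(/C=C3/CC3(CO)CO)c2n1`) stands at a limit of the assay (> 20000 nM). For the measured compounds named here, compound 2 (`CCCCCCCCSc1nc(N)nc2c1ncn2/C=C1/CC1(CO)CO`) gives 60000 nM as the only actual number, so it cannot be ranked. Compound 3 (`Nc1nc(SC2CCCC2)c2ncn(/C=C3/CC3(CO)CO)c2n1`) carries cyclopentyl in place of octyl on a sulfur. Going by the values given here, the only measured step (a step that the limit leaves unreadable from compound 1 to compound 2) involves a different change and offers no usable size. Compound 2 at 60000 nM is therefore the sole anchor for this expectation. No change beyond the scatter is expected (a 1.2-fold higher number from compound 2 to compound 3 (0.07 log units; within the scatter)). Compound 3 is expected to read 70000 nM and estimated to fall from 25000 nM to 150000 nM when measured.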

Compound 3, half-maximal cytotoxic concentration: 91000 nM
The estimate for compound 3 lay 1.3-fold (0.11 log units) below the measured number; the measured number falls inside the stated range.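

In this assay, cyclopentyl in place of octyl on a sulfur gives a 1.5-fold higher number from compound 2 to compound 3 (0.18 log units; within the scatter). On this sulfur, then, the octyl chain and the cyclopentyl ring are not told apart by this read-out, although the two groups differ in size and in having a ring.

From the compounds shown here alone, whether a group such as an amine or a carboxylic acid at the end of a chain on the sulfur would move the number beyond the scatter stays open. The steps from compound 1 cannot be read, so cyclopentylsulfanyl and cyclopentylamino stay uncompared, as compound 1 gives > 20000 nM, a limit of the assay and not a number: the limit of > 20000 nM in this assay, at which 1 of the 3 values shown sits.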